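Swapping a Hydroxyethyl Amide Tail for a Hydrazide

This account rests on a few compounds, and the source may have more. Where it says the series, first, only, none or still open, it means among the compounds named here.

Of the compounds shown here, two built on one shared core have been tested in a functional assay on HCT-116 cells (Homo sapiens) for cytotoxicity, read by MTT assay, with a stated time of 72 h; a lower number here means a stronger inhibitor, a higher number a weaker inhibitor. Compound 1 `CCOc1ccc2cc(C(=O)NCCO)c(=O)oc2c1` gives in this assay > 100000 nM, which is a limit of the assay and not a measured number. Compound 2 `CCCOc1ccc2cc(C(=O)NCCO)c(=O)oc2c1` gives in this assay > 100000 nM, again a limit rather than a number. The step that the two limits leave unreadable from compound 1 to compound 2 therefore cannot be read, since (the limit of > 100000 nM in this assay, at which 2 of the 2 values shown sit).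

Compound 3 `CCCOc1ccc2cc(C(=O)NN)c(=O)oc2c1` has not yet been measured. It differs from compound 2 by amino in place of 2-hydroxyethyl on an amide-type nitrogen. No measured step touches this part of the molecule, so nothing shown here indicates a direction for the number to move. Among the measured compounds shown here, the only anchor is that compound 2 sits at a limit of this assay. Compound 3 is therefore expected to stay near that limit, at an estimated 150000 nM, with a range from 40000 nM to 600000 nM. The expected step that the limit leaves unreadable from compound 2 to compound 3 is small, and most likely this assay will again report only a limit.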

Compound 3, half-maximal inhibitory concentration: 69800 nM
Compound 3: the middle estimate sits 2.1-fold (0.33 log units) above what was measured; low and high end bracket the measured number.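

In this assay, amino in place of 2-hydroxyethyl on the amide-type nitrogen gives an at least 1.4-fold lower number from compound 2 to compound 3 (0.15 log units; that floor lies within the scatter). Among the compounds shown here, this is the first readable signal, since compound 3 is the only one of the three compounds with a number rather than a limit. The change brings the value into the range the assay can read, but the true size of the step stays unknown and its floor lies within the scatter, because the starting value is only a limit: the limit of > 100000 nM in this assay, at which 2 of the 3 values shown sit.

As far as these compounds go, it remains open whether methylamino or dimethylamino on that nitrogen would move the number further. From the compounds shown here alone, it is also open whether a longer chain, at the place where compound 1 and compound 2 differ, would shift the value of compound 3.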